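Amide tail variation on the shared core

A few compounds are considered here, and "the series" means these few. Any claim that something is new, unique, unknown or untested is made for them only; others in the source may bear on it.

Measured so far, in an assay for inhibition of 6-phosphofructo-2-kinase/fructose-2,6-bisphosphatase 3 (Homo sapiens), read by ADP-Glo, with a stated time of 2 h; on this read-out higher numbers stand for weaker inhibition and lower numbers for stronger inhibition:
compound 1 `Cn1ccc2ccc(-c3cc(Nc4ccccc4S(N)(=O)=O)cc4nccnc34)cc21`, 265 nM
compound 2 `CNS(=O)(=O)c1ccccc1Nc1cc(-c2ccc3ccn(C)c3c2)c2nccnc2c1`, 104 nM
compound 3 `CN1CCC(NC(=O)c2ccncc2Nc2cc(-c3ccc4ccn(C)c4c3)c3nccnc3c2)CC1`, 38 nM

Compound 3 holds the lowest number of the three; compound 2 sits nearest to it and compound 1 furthest, both gaps lying beyond the scatter. For the measured compounds named here, the only single-point step among the measured compounds is a 2.5-fold lower number from compound 1 to compound 2 (0.41 log units; beyond the scatter), which concerns a sulfonamide nitrogen that compound 3 no longer carries.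

Compound 4 `Cn1ccc2ccc(-c3cc(Nc4cnccc4C(=O)NCC4COCCN4)cc4nccnc34)cc21` differs from compound 3 in one place: (morpholin-3-yl)methyl in place of 1-methylpiperidin-4-yl on an amide-type nitrogen. Going by the values given here, no measured step touches this amide-type nitrogen, so the series gives no direct read on the change; the step from compound 1 to compound 2 is on a different part of the molecule and is used here only as a sign that small peripheral swaps have moved this assay by modest amounts. With that limited basis, a step of about a 1.3-fold higher number from compound 3 to compound 4 (0.12 log units; within the scatter) is expected, of uncertain direction and not far beyond the scatter. Compound 4 is therefore estimated at 50 nM, within a range of 15 nM to 170 nM.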

Compound 4, half-maximal inhibitory concentration: 33 nM
Compound 4: middle estimate off by 1.5-fold (0.18 log units), on the high side; measured number inside the range.
By their numbers in this assay, from the lowest: compounds 4 and 3 (each within the scatter of the next); then compound 2; then compound 1.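

In this assay the amide-type nitrogen now has its first measured step, a 1.2-fold lower number from compound 3 to compound 4 (0.06 log units; within the scatter), so the values for this pair cannot be told apart and this position accepts (morpholin-3-yl)methyl in place of 1-methylpiperidin-4-yl without a shift beyond the scatter. The swap keeps the count of 7 heavy atoms but replaces a six-membered non-aromatic ring with 1 hetero atom by one with 2 hetero atoms, and goes from 0 hydrogen-bond donors to 1 hydrogen-bond donor, so these differences in the tail leave no readable trace on this read-out for this pair. No measurement at hand offers an explanation for this result.

For the compounds shown here, the single step does not separate the contribution of the ring from that of the methyl link, so a directly attached morpholin-3-yl or a 1-methylpiperidin-4-ylmethyl group on the same nitrogen would be needed to pull the two apart. Also open, going by these compounds, is how far this tolerance extends beyond six-membered rings, for instance to an open-chain 2-(dimethylamino)ethyl group, a carboxylic acid at the end of a longer chain, or a plain methyl group on this nitrogen.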